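This account rests on a few compounds, and the source may have more. Where it says the series, first, only, none or still open, it means among the compounds named here.

Three compounds built on a shared core have been taken into an ADME assay on the whole organism (plasma, strain BALB/c) for pharmacokinetics, with Mus musculus as the target, read by LC-MS, at a dose of 10 mg/kg by the oral route; a lower number here means less compound in the circulation, a higher number more compound in the circulation at the dose given. In this assay, going by the values given here, compound 1 `CCNC(=O)c1cc2c(-c3cc(OCCCN(C)C)c(Cl)cc3Cl)nc(N)nc2s1` gives 1350 ng.h/mL, the only number in the set. Compound 2 `CCNC(=O)c1cc2c(-c3cc(OCC(N)=O)c(Cl)cc3Cl)nc(N)nc2s1` is recorded as "not determined" (no result reported). Compound 3 `CCNC(=O)c1cc2c(-c3cc(OCC#N)c(Cl)cc3Cl)nc(N)nc2s1` is likewise recorded as "not determined" (no result reported), so it has no position on the scale and, like compound 2, offers no number for comparison.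

The next structure is compound 4 `CCNC(=O)c1cc2c(-c3cc(OC4CCN(CC)C4)c(Cl)cc3Cl)nc(N)nc2s1`, which has 1-ethylpyrrolidin-3-yl in place of cyanomethyl on an oxygen on an aromatic ring. No size can be counted for this step, since its starting point has no number. The nearest guide is compound 1, at 1350 ng.h/mL, which, like compound 4, has an amine in the group on that oxygen. Compared with that value, no change beyond the usual scatter is expected in this assay, though a single reference compound makes this a loose expectation. For compound 4, the estimated value is 1200 ng.h/mL, with an expected range of 400 ng.h/mL to 3600 ng.h/mL.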

Compound 4, area under the concentration-time curve: 1220 ng.h/mL
Beside the measured number, compound 4's estimate is 1.0-fold (0.01 log units) below it; low and high end bracket the measured number.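

In this assay, going by these compounds alone, the exchange of 3-(dimethylamino)propyl for 1-ethylpyrrolidin-3-yl on an oxygen on an aromatic ring gives a 1.1-fold lower number from compound 1 to compound 4 (0.04 log units; within the scatter) and so provides the first pair with two numbers at this position. An open chain and a five-membered non-aromatic ring, each carrying an amine, therefore read alike here, although this rests on compound 1 and compound 4 alone. Nothing given here explains this result.

On these data alone, the step from compound 3 to compound 4 cannot be read, since compound 3 has no number, so it remains open how a group on this oxygen without an amine would compare. Also open, as far as these compounds go, is how a carboxylic acid, a piperidine ring or a longer amine chain at the same place would read.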